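The source may report more compounds than this note shows. Statements on the series, on what has been measured and on what is new or still open speak of the compounds shown alone.

The measured compounds:

Compound 1, `Cn1c(=O)c2[nH]c(SCC(=O)c3ccc(Br)cc3)nc2n(C)c1=O`, gives 6500 nM in a functional assay on HT-29 cells (Homo sapiens) for inhibition, read by MTT assay, with a stated time of 48 h; on this read-out higher numbers stand for weaker inhibition and lower numbers for stronger inhibition.
Compound 2, `Cn1c(=O)[nH]c2nc(SCC(=O)c3ccc(Br)cc3)[nH]c2c1=O`, gives 11500 nM in this assay.
Compound 3, `Cn1c(=O)c2[nH]c(SC/C(=N/O)c3ccccc3)nc2n(C)c1=O`, gives 6700 nM in this assay.

Compound 1 and compound 2 share a core and differ in only one place: hydrogen in place of methyl on an aromatic nitrogen. This single change gave a 1.8-fold higher number from compound 1 to compound 2 (0.25 log units; within the scatter), so the two compounds cannot be told apart on this read-out. Compound 3 carries a different side chain from compound 1; the difference between the two cores is not broken down here. Its value and the value of compound 1 lie within the scatter of each other, so nothing separates them either.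

Compound 4, `Cn1c(=O)[nH]c2nc(SC/C(=N/O)c3ccccc3)[nH]c2c1=O`, has not yet been measured in this assay. It stands to compound 3 exactly as compound 2 stands to compound 1, through the same change: hydrogen in place of methyl on an aromatic nitrogen. This change appears twice among the compounds shown, and the one measured instance is the step from compound 1 to compound 2. A step of about the same small size is expected on the second occasion, because the change produced a 1.8-fold higher number from compound 1 to compound 2 (0.25 log units; within the scatter) the first time, a shift too small to count as real. The expected step is a 1.6-fold higher number from compound 3 to compound 4 (0.22 log units; within the scatter). Compound 4 is therefore estimated at 11000 nM, with a likely range from 5000 nM to 25000 nM.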

Compound 4, half-maximal inhibitory concentration: 2100 nM
Estimate against measurement, compound 4: 5.2-fold (0.72 log units) above, and the stated range ends above it.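

In this assay, putting hydrogen in place of methyl on the aromatic nitrogen gives a 3.2-fold lower number from compound 3 to compound 4 (0.50 log units; beyond the scatter), a modest change that stands out from the usual variation between repeated measurements and points to stronger inhibition on this core. The same change therefore does not carry a fixed effect from one core to the other, and its size measured on one core would have been a poor guide to its size on the other: the same change on two cores in this assay, a 1.8-fold higher number (0.25 log units; within the scatter) from compound 1 to compound 2 and a 3.2-fold lower number (0.50 log units; beyond the scatter) from compound 3 to compound 4, 5.6-fold (0.75 log units) apart, beyond the scatter of two such steps. This does not show that the change truly reverses direction, since the earlier step alone cannot be told from scatter, and two pairs cannot show how the change would behave on other cores or why the two steps differ.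

As far as these compounds go, the two side chains differ both in the bromine on the phenyl ring and in the ketone carbonyl as against the oxime, so it stays open which of these features goes with the larger step. Also open, from the compounds shown here alone, is what a longer chain on that nitrogen, such as ethyl or propyl in place of methyl, would do on each core, and whether inhibition keeps following the size of that group.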